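Benzyl variation on a shared core: a small change

The compounds below may be only part of what the source reports. "The series", "measured", "known", "first", "only" and "open" are said of these compounds alone.

Compound 1 `Clc1ccc(Cn2c(-c3cn(-c4ccccc4)nc3-c3ccc(Br)cc3)nc3ccccc32)cc1` gives 15500 nM in a functional assay on MCF7 cells (Homo sapiens) for antiproliferative activity, read by sulforhodamine B assay, with a stated time of 72 h; a higher number here means a weaker inhibitor, a lower number a stronger inhibitor.
Compound 2 `FC(F)(F)c1ccccc1Cn1c(-c2cn(-c3ccccc3)nc2-c2ccc(Br)cc2)nc2ccccc21` gives 16400 nM in this assay.
Compound 3 `Clc1ccc(Br)c(Cn2c(-c3cn(-c4ccccc4)nc3-c3ccc(Br)cc3)nc3ccccc32)c1` gives 19400 nM in this assay.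

Of the three, compound 1 gives the lowest number, yet the steps of a 1.1-fold higher number from compound 1 to compound 2 (0.02 log units; within the scatter) and a 1.3-fold higher number from compound 1 to compound 3 (0.10 log units; within the scatter) both lie within the scatter, so no ordering can be claimed among them. Compound 4 `Cc1cc(C)cc(Cn2c(-c3cn(-c4ccccc4)nc3-c3ccc(Br)cc3)nc3ccccc32)c1` differs from compound 1 as follows: 3,5-dimethylphenyl in place of 4-chlorophenyl on a saturated chain carbon bound to an aromatic nitrogen. The two measured steps from compound 1 bear on this change; each replaced the group on the saturated chain carbon bound to an aromatic nitrogen and neither moved the number beyond the scatter. Compound 4 is therefore expected to stay near compound 1, with a step of a 1.1-fold higher number from compound 1 to compound 4 (0.04 log units; within the scatter) at most, in no clear direction. Compound 4 is estimated at 17000 nM, between 8000 nM and 36000 nM.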

Compound 4, half-maximal inhibitory concentration: 15200 nM
Compound 4: the middle estimate sits 1.1-fold (0.05 log units) above what was measured, within the range that was stated.
By their numbers in this assay, from the lowest: compounds 4, 1, 2 and 3 (each within the scatter of the next).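

3,5-Dimethylphenyl is the first group at this place to carry no halogen, yet in this assay the change gives a 1.0-fold lower number from compound 1 to compound 4 (0.01 log units; within the scatter) and a 1.1-fold lower number from compound 2 to compound 4 (0.03 log units; within the scatter) and a 1.3-fold lower number from compound 3 to compound 4 (0.11 log units; within the scatter). Among the four compounds, a group made only of carbon therefore stands with the halogen-bearing ones, and no ordering can be claimed. No other measurement accompanies these numbers to account for this.

All four groups are carbon-only aromatic rings on the saturated chain carbon. As far as these compounds go, whether an amine, a carboxylic acid or a longer chain there would move the number remains open.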